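A few compounds are considered here, and "the series" means these few. Any claim that something is new, unique, unknown or untested is made for them only; others in the source may bear on it.

Compound 1 `O=C(CSc1nnnn1-c1ccccc1)N/N=c1/scc(-c2ccc(Br)cc2)n1-c1ccccc1` is one of two compounds tested in a functional assay on C6 cells (Rattus norvegicus) for cytotoxicity, read by MTT assay, with a stated time of 24 h, tested at 50 ug/mL (a lower number here means a stronger effect, a higher number a weaker effect of the compound at the concentration tested), where compound 1 gives 32%. Within the data shown here, its only companion is compound 2 `O=C(CSc1ncccn1)N/N=c1/scc(-c2ccc(Br)cc2)n1-c1ccccc1`, which in this assay gives 69%. Among the measured compounds shown here, the single known step is a number 37 percentage points higher from compound 1 to compound 2 (beyond the scatter), and it changes the group on the sulfur, not the aryl ring that now comes into question.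

Compound 3 `N#Cc1ccc(-c2cs/c(=N/NC(=O)CSc3nnnn3-c3ccccc3)n2-c2ccccc2)cc1` differs from compound 1 by cyano in place of bromo on an aromatic carbon. For the measured compounds named here, no measured step touches this position: the step from compound 1 to compound 2 concerns a different part of the molecule, so it offers no direct guide. What it does show is that this scaffold can move over a wide span in this assay. With nothing to anchor the direction, the step from compound 1 to compound 3 is expected to stay near or only modestly above the scatter, a number 8 percentage points higher from compound 1 to compound 3 (within the scatter). Compound 3 is therefore estimated at 40% in this assay, with a range from 22% to 62%.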

Compound 3, a percentage reported as activity, at one concentration (the size of the read-out at that concentration, not a potency): 61.1%
Compound 3: the middle estimate sits 21.1 percentage points below what was measured; low and high end bracket the measured number.
By their numbers in this assay, from the lowest: compound 1; then compounds 3 and 2 (each within the scatter of the next).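

The change from 4-bromophenyl to 4-cyanophenyl shows that this aromatic carbon, para to a large group, is not a silent place in this assay: cyano in place of bromo gives a number 29.1 percentage points higher from compound 1 to compound 3 (beyond the scatter). Only the group on the sulfur had been seen to move this read-out before, so the aryl ring is now a second place where a single change counts, and of this pair the bromo compound has the stronger effect at the concentration tested. No evidence is at hand to explain why this exchange moves the number.

Going by these compounds, how an amine or a carboxylic acid on the same carbon would read remains open. Also open, on these data alone, is whether cyano in place of bromo would move the number the same way with the pyrimidin-2-yl on the sulfur, as in compound 2.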